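Swapping nitro for methoxy on a sulfonylurea receptor inhibitor core

The source may report more compounds than this note shows. Statements on the series, on what has been measured and on what is new or still open speak of the compounds shown alone.

The measured compounds in a functional assay for inhibition of sulfonylurea receptor 1, Kir6.2 (Homo sapiens) (on this read-out lower numbers stand for an effect already at smaller amounts and higher numbers for an effect only at larger amounts of compound), are:
compound 1, `O=[N+]([O-])c1ccc2c(c1)S(=O)(=O)NC(NC1CCC1)=N2`, with 530 nM;
compound 2, `O=S1(=O)N=C(NC2CCC2)Nc2ccccc21`, with 1960 nM;
compound 3, `O=S1(=O)NC(NC2CCC2)=Nc2ccc(F)cc21`, with 356 nM.

Compound 1 stands second highest of these three numbers. Its nearest neighbour is compound 3, and the step of a 1.5-fold lower number from compound 1 to compound 3 (0.17 log units; within the scatter) lies within the scatter of this assay. Compound 2, which carries no group on the benzene ring of the shared core, gives a number beyond the scatter above that of compound 1.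

Compound 4, `COc1ccc2c(c1)S(=O)(=O)NC(NC1CCC1)=N2`, has not yet been measured. It differs from compound 1 in one place: methoxy in place of nitro on an aromatic carbon. Within the data shown here, the only measured step that bears on this change is the one from compound 1 to compound 3, where a different group replaced the same nitro, and that step stayed within the scatter. Among the measured compounds shown here, no measured compound carries a methoxy, so the expectation rests on that single comparison. A small step, in either direction or none beyond the scatter, is expected in this assay. For compound 4 the estimated value is 700 nM, with a range from 250 nM to 2000 nM. The expected step is then a 1.3-fold higher number from compound 1 to compound 4 (0.12 log units; within the scatter).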

Compound 4, half-maximal effective concentration: 3870 nM
Beside the measured number, compound 4's estimate is 5.5-fold (0.74 log units) below it, outside the stated range (above it).
By their numbers in this assay, from the lowest: compounds 3 and 1 (each within the scatter of the next); then compounds 2 and 4 (each within the scatter of the next).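

In this assay, this aromatic carbon proves sensitive to which group it carries: a 7.3-fold higher number from compound 1 to compound 4 (0.86 log units; beyond the scatter) with methoxy in place of nitro, whereas fluoro in place of the same nitro gave only a 1.5-fold lower number from compound 1 to compound 3 (0.17 log units; within the scatter). The direct comparison of the two replacements gives an 11-fold higher number from compound 3 to compound 4 (1.04 log units; beyond the scatter), and compound 4 falls within the scatter of compound 2, which has no group on this ring, so in this small set, nitro and fluoro share a range that methoxy does not reach. No measurement shown here explains why methoxy behaves differently.

From the compounds shown here alone, whether an amine, a chlorine or a trifluoromethyl on this carbon would fall with nitro and fluoro or with methoxy remains open. So does whether a longer ether, such as ethoxy, would follow methoxy.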